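A few compounds are considered here, and "the series" means these few. Any claim that something is new, unique, unknown or untested is made for them only; others in the source may bear on it.

In an ADME assay on microsomes from liver (Homo sapiens) for metabolic stability, with a stated time of 60 min, tested at 1 uM (on this read-out higher numbers stand for a more stable compound and lower numbers for a less stable compound), the measured compounds give
compound 1 `COc1cc(-c2cnn3cc(OC)c(-c4cnn(C)c4)nc23)ccn1` gives 43%
compound 2 `COc1cc(-c2cnn3cc(OC)c(C(C)C)nc23)ccn1` gives 40%
compound 3 `COc1cc(-c2cnn3cc(OC)c(C4CCOC4)nc23)ccn1` gives 29%

Compound 1 stands at the upper end of this set, but its nearest step (a number 3 percentage points lower from compound 1 to compound 2 (within the scatter)) does not separate it. Its furthest step is a number 14 percentage points lower from compound 1 to compound 3 (beyond the scatter) and the remaining one is a number 11 percentage points lower from compound 2 to compound 3 (beyond the scatter). Compound 4 `COc1cn2ncc(-c3ccnc(OC(C)(C)C)c3)c2nc1-c1cnn(C)c1` keeps the core of compound 1 and carries one change (tert-butyl in place of methyl on an oxygen on an aromatic ring), methoxy to tert-butoxy. Among the compounds with values here, no measured step touches that place, so these steps serve only as a rough guide to size. A modest fall is expected, with weak support, as compound 3 moved by no more than a number 14 percentage points lower from compound 1 to compound 3 (beyond the scatter) at another place. The expected change is a number 10 percentage points lower from compound 1 to compound 4 (within the scatter) and could still lie within the scatter. For compound 4 the estimate is 33% (expected range 15% to 52%).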

Compound 4, percent of the compound remaining: 35%
For compound 4 the middle estimate is 2 percentage points below the measured one, and the stated range covers the measured number.
By their numbers in this assay, from the lowest: compounds 3, 4, 2 and 1 (each within the scatter of the next, the first and the last beyond it).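

In this assay, the first step read at this oxygen on the aromatic ring, methoxy to tert-butoxy, is a number 8 percentage points lower from compound 1 to compound 4 (within the scatter), so the read-out does not separate tert-butyl from methyl at this place. No supporting data bear on why the two groups read alike. On these data alone, what an amine or an ethoxy group would give in place of methoxy stays open. Also open, as far as these compounds go, is whether tert-butoxy reads the same alongside the isopropyl of compound 2 or the oxolan-3-yl of compound 3.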